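Diaryl urea series: hydroxy in place of methoxy on compound 2

The compounds below may be only part of what the source reports. "The series", "measured", "known", "first", "only" and "open" are said of these compounds alone.

Measured so far:
compound 1, `Cc1ccc(NC(=O)Nc2ccc(Cl)c(C(F)(F)F)c2)cc1O`: in a functional assay on cells (Mus musculus) for antiproliferative activity, read by sulforhodamine B assay, with a stated time of 5 days (a lower number here means a stronger inhibitor, a higher number a weaker inhibitor), compound 1 gives > 20000 nM, a limit of the assay rather than a number.
compound 2, `COc1cc(NC(=O)Nc2ccc(Cl)c(Cl)c2)ccc1C`: in this assay compound 2 gives > 20000 nM, likewise a limit and not a number.

Compound 2 therefore stands only at a limit, and every value shown so far sits there too (the limit of > 20000 nM in this assay, at which 2 of the 2 values shown sit). Compound 3, `Cc1ccc(NC(=O)Nc2ccc(Cl)c(Cl)c2)cc1O`, differs from compound 2 by hydrogen in place of methyl on an oxygen on an aromatic ring. Within the data shown here, no step between measured compounds exists for comparison. No change beyond the scatter is expected in this assay; the expected step of a number no higher from compound 2 to compound 3 (the limit leaves the size open) is essentially none, with compound 3 most likely again reported as a limit. Compound 3 is estimated at 20000 nM, within 8000 nM to 60000 nM.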

Compound 3, half-maximal inhibitory concentration: > 20000 nM
Compound 3: no number, only a limit; the forecaster's own chance of this, stated with the estimate: 80%; the middle value sits exactly at the limit.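

No step can be read among compound 1, compound 2 and compound 3, each reported only as a limit: the limit of > 20000 nM in this assay, at which 3 of the 3 values shown sit.

As far as these compounds go, what the swap of methoxy to hydroxy, or of trifluoromethyl to chloro, does to the read-out in this assay stays open.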